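The source may hold more compounds than are shown below. What is called first, only, known or untested is meant among the compounds shown, and "the series" means these compounds.

Compound 1 `C[C@H](NC(=O)Nc1cccc(F)c1)c1ccccc1` gives 88%
Compound 2 `C[C@@H](NC(=O)Nc1ccc(F)cc1)c1ccccc1` gives 92%
Compound 3 `C[C@H](NC(=O)Nc1cccc(F)c1F)c1ccccc1` gives 100%

All three were measured in an ADME assay on the whole organism with Oryza sativa as the target, tested at 10 uM; on this read-out higher numbers stand for a weaker effect at the one concentration tested and lower numbers for a stronger effect. Compound 1 and compound 2 share their atoms joined differently; the difference between the two cores is not broken down here, and their values lie within the scatter of each other. From compound 1 to compound 3 the change fluoro in place of hydrogen on an aromatic carbon produced a number 12 percentage points higher from compound 1 to compound 3 (beyond the scatter). Compound 4 `C[C@@H](NC(=O)Nc1ccc(F)cc1F)c1ccccc1` has not yet been measured in this assay ; it differs from compound 2 by fluoro in place of hydrogen on an aromatic carbon. This is the same kind of change, not the same: in compound 3 the entering fluoro sits ortho to a fluoro group and ortho to a large group, whereas in compound 4 it sits ortho to a large group and meta to a fluoro group. Because a number 12 percentage points higher from compound 1 to compound 3 (beyond the scatter) was modest, a step of about a number 6 percentage points higher from compound 2 to compound 4 (within the scatter) is expected for compound 4. Compound 4 is therefore estimated at 98%, between 88% and 105%.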

Compound 4, a percentage reported as activity, at one concentration (the size of the read-out at that concentration, not a potency): 93%
Compound 4: middle estimate off by 5 percentage points, on the high side; the measured number falls inside the stated range.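

In this assay, fluoro in place of hydrogen on an aromatic carbon gave a number 1 percentage points higher from compound 2 to compound 4 (within the scatter). Set beside the earlier step, the result gives no sign that the change behaves differently on the two cores: the same change on two cores in this assay, a number 12 percentage points higher (beyond the scatter) from compound 1 to compound 3 and a number 1 percentage points higher (within the scatter) from compound 2 to compound 4, 11 percentage points apart, within the scatter of two such steps. Among the compounds shown here, this does not show that the step carries over at a fixed size: there are only two pairs, one step lies beyond the scatter and the other within it, and the entering fluoro does not sit in the same place in both.

The compounds shown carry only fluoro as a substituent on the aromatic ring. On these data alone, how a chloro, a methoxy or an amine in those places would read in this assay remains open.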